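Methoxy for fluoro on the anilino ring: cytotoxicity outlook

The source may hold more compounds than are shown below. What is called first, only, known or untested is meant among the compounds shown, and "the series" means these compounds.

Of the compounds shown here, two have been tested in an ADME assay on THP-1 cells (Homo sapiens) for cytotoxicity; a lower number here means that less compound is tolerated, a higher number that more compound is tolerated. Compound 1 `c1ccc(-c2nc3ccccn3c2NCC2CC2)nc1` gives 19400 nM. Compound 2 `Cc1ccc2nc(-c3ccccn3)c(Nc3ccc(F)cc3)n2c1` gives 9610 nM, the lowest of the two numbers; its distance to compound 1 lies beyond the scatter, so compound 2 is tolerated at a lower concentration than compound 1. For the measured compounds named here, no pair of measured compounds differs in a single place, so no measured step is available to guide the next one. Compound 3 `COc1ccc(Nc2c(-c3ccccn3)nc3ccc(C)cn23)cc1` is yet to be measured. It differs from compound 2 by methoxy in place of fluoro on an aromatic carbon. With nothing in the measured set speaking to this exchange, the expected step of a 1.1-fold lower number from compound 2 to compound 3 (0.03 log units; within the scatter) is estimated as none beyond the scatter. For compound 3 the expected value is 9000 nM, with a range from 4000 nM to 20000 nM.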

Compound 3, half-maximal cytotoxic concentration: 10700 nM
The estimate for compound 3 lay 1.2-fold (0.08 log units) below the measured number, and the stated range covers the measured number.
By their numbers in this assay, from the lowest: compounds 2, 3 and 1 (each within the scatter of the next, the first and the last beyond it).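

The change from 4-fluorophenyl to 4-methoxyphenyl gives the series its first single-place step, a 1.1-fold higher number from compound 2 to compound 3 (0.05 log units; within the scatter) in this assay. At this position, on an aromatic carbon para to a large group, the read-out does not separate methoxy, with 2 heavy atoms and 1 hydrogen-bond acceptor, from fluoro, with 1 heavy atom and 0 hydrogen-bond acceptors. No supporting measurement bears on why this exchange reads as it does.

As far as these compounds go, whether this position tolerates groups of a different kind, such as an amine or a carboxylic acid, as it does these two, remains open. Compound 1 differs from compound 2 and compound 3 in more than one place, so its higher number cannot be assigned to any single change.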